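Swapping the amide-chain tail for an ester-bearing ring

The source may report more compounds than this note shows. Statements on the series, on what has been measured and on what is new or still open speak of the compounds shown alone.

Of the compounds shown here, three sharing one core have been measured in an assay on HEK293 cells for displacement of a labelled ligand from NPC1-like intracellular cholesterol transporter 1 (Homo sapiens); on this read-out higher numbers stand for weaker inhibition and lower numbers for stronger inhibition. Compound 1 `CC(C)(C)c1ccc(C(=O)N2CCC3(CC2)C(=O)N(CC(=O)NCCN)CN3c2ccccc2)cc1` gives 7000 nM; compound 2 `CCC1CCCN(C(=O)CN2CN(c3ccccc3)C3(CCN(C(=O)c4ccc(C(C)(C)C)cc4)CC3)C2=O)C1` gives 3900 nM; compound 3 `CC(C)(C)c1ccc(C(=O)N2CCC3(CC2)C(=O)N(CC(=O)NCNS(C)(=O)=O)CN3c2ccccc2)cc1` gives 3200 nM. The step from compound 1 to compound 3 was a 2.2-fold lower number from compound 1 to compound 3 (0.34 log units; beyond the scatter), so compound 3 sits beyond the scatter from compound 1, while against compound 2 the step was only a 1.2-fold lower number from compound 2 to compound 3 (0.09 log units; within the scatter), placing these two within the scatter of each other.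

Compound 4 `CCOC(=O)C1CCCN(C(=O)CN2CN(c3ccccc3)C3(CCN(C(=O)c4ccc(C(C)(C)C)cc4)CC3)C2=O)C1` differs from compound 3 in one place: 3-(ethoxycarbonyl)piperidin-1-yl in place of ((methanesulfonamido)methyl)amino on a carbonyl carbon. Two earlier steps bear on this exchange of an open amide chain for a piperidinyl ring at the same carbonyl carbon. From compound 1 to compound 2 the step was a 1.8-fold lower number from compound 1 to compound 2 (0.25 log units; within the scatter), and from compound 2 to compound 3 it was a 1.2-fold lower number from compound 2 to compound 3 (0.09 log units; within the scatter); both lie within the scatter. Among the compounds with values here, the 3-(ethoxycarbonyl)piperidin-1-yl group of compound 4 has no measured precedent, so its ester is an untested element. A step of about a 1.3-fold higher number from compound 3 to compound 4 (0.10 log units; within the scatter) is therefore expected, essentially no change beyond the scatter. For compound 4 in this assay the estimated value is 4000 nM, with a range from 1800 nM to 9000 nM.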

Compound 4, half-maximal inhibitory concentration: 8200 nM
Compound 4: middle estimate off by 2.1-fold (0.31 log units), on the low side, within the range that was stated.
By their numbers in this assay, from the lowest: compounds 3, 2, 1 and 4 (each within the scatter of the next, the first and the last beyond it).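

Within the data shown here, the clearest reading comes from the comparison in this assay of ethoxycarbonyl with ethyl on a saturated ring carbon: the change gives a 2.1-fold higher number from compound 2 to compound 4 (0.32 log units; beyond the scatter) and shows for the first time that what the piperidine ring carries can matter here, since the ester form inhibits more weakly than the ethyl form. The ring exchange at the carbonyl carbon also depends on which open chain it replaces, since swapping out the ((methanesulfonamido)methyl)amino chain gives a 2.6-fold higher number from compound 3 to compound 4 (0.41 log units; beyond the scatter) and counts as a real loss, whereas swapping out the (2-aminoethyl)amino chain gives a 1.2-fold higher number from compound 1 to compound 4 (0.07 log units; within the scatter) and cannot be told apart from no change. Nothing in the available data explains why the ester weakens inhibition on this read-out.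

Still open, on these data alone, is whether the loss belongs to the ester as such, which a carboxylic acid or a primary amide on the same saturated ring carbon would help to test. A plain piperidin-1-yl group with nothing on the ring would also show whether the ethyl group of compound 2 contributes anything at all.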